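Aryl swap on the ring amide nitrogen: compound 3

A few compounds are considered here, and "the series" means these few. Any claim that something is new, unique, unknown or untested is made for them only; others in the source may bear on it.

Measured so far:
compound 1 `CC(C)[C@@H]1CC[C@@H](C)C[C@@]12N(C)C(=O)[C@@H]1[C@H]3C(=O)NC(=O)[C@H]3ON12`: 70%
compound 2 `Cc1cccc(N2C(=O)[C@H]3[C@H](ON4[C@@H]3C(=O)N(C)[C@@]43C[C@H](C)CC[C@H]3C(C)C)C2=O)c1`: 47.7%

Both numbers come from a functional assay, read by spectrophotometry, with a stated time of 2 h, tested at 2.5 mg/mL; a higher number here means a stronger effect of the compound at the concentration tested, a lower number a weaker effect. Among the measured compounds shown here, compound 2 stands lowest of the two numbers; the only measured step, a number 22.3 percentage points lower from compound 1 to compound 2 (beyond the scatter), is the change from hydrogen to 3-methylphenyl on the ring amide nitrogen. Compound 3 `CC(C)[C@@H]1CC[C@@H](C)C[C@@]12N(C)C(=O)[C@@H]1[C@H]3C(=O)N(c4ccc5ccccc5c4)C(=O)[C@H]3ON12` carries naphthalen-2-yl in place of 3-methylphenyl on an amide-type nitrogen in a ring. For the measured compounds named here, no measured step exchanges one aryl group for another, so that step bears on it only loosely; a change within the scatter or a modest further drop in this assay is expected. Compound 3 is estimated at 42% (range 25% to 60%), which is an expected step of a number 5.7 percentage points lower from compound 2 to compound 3 (within the scatter).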

Compound 3, a percentage reported as activity, at one concentration (the size of the read-out at that concentration, not a potency): 47.9%
The estimate for compound 3 lay 5.9 percentage points below the measured number, and the stated range covers the measured number.
By their numbers in this assay, from the lowest: compounds 2 and 3 (each within the scatter of the next); then compound 1.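

In this assay naphthalen-2-yl in place of 3-methylphenyl on the ring amide nitrogen gives a number 0.2 percentage points higher from compound 2 to compound 3 (within the scatter) and so does not separate the two aryl groups. Naphthalen-2-yl in place of hydrogen at this nitrogen gives a number 22.1 percentage points lower from compound 1 to compound 3 (beyond the scatter) and shows that the drop is not confined to 3-methylphenyl, as both aryl compounds sit below compound 1. No supporting data explain this result.

As far as these compounds go, whether the drop needs an aryl group at all remains open. Methyl or a longer alkyl chain on this nitrogen, or a phenyl bearing an amine or a carboxylic acid, would bear on that.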